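Trading a Semicarbazide Link for a Direct Aryl Urea

The source may hold more compounds than are shown below. What is called first, only, known or untested is meant among the compounds shown, and "the series" means these compounds.

Compound 1 `COc1cc(NC(C)CCCNC(=O)NNC(=O)Nc2ccc(Br)cc2)c2ncccc2c1`: 27000 nM
Compound 2 `COc1cc(NC(C)CCCNC(=O)Nc2cccc(Cl)c2)c2ncccc2c1`: 37000 nM
Compound 3 `COc1cc(NC(C)CCCNC(=O)NNC(=O)Nc2ccc(Cl)cc2)c2ncccc2c1`: 63000 nM

These three compounds share one core and differ only in the tail attached to the amide-type nitrogen. In a functional assay on NCI-H460 cells (Homo sapiens) for inhibition, read by MTT assay, with a stated time of 72 h (on this read-out higher numbers stand for weaker inhibition and lower numbers for stronger inhibition), compound 3 gives the highest of the three numbers; its gap to compound 2 is within the scatter, while its gap to compound 1 is beyond it, though modest.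

Compound 4 `COc1cc(NC(C)CCCNC(=O)Nc2ccc(Cl)cc2)c2ncccc2c1` is not yet measured. It differs from compound 3 by 4-chlorophenyl in place of ((4-chlorophenyl)carbamoyl)amino on an amide-type nitrogen. The change sits on an amide-type nitrogen whose other neighbour is a carbonyl carbon.

Within the data shown here, two measured steps bear on this. The step of a 1.7-fold higher number from compound 2 to compound 3 (0.23 log units; within the scatter) is the same kind of change run backwards, and the step of a 1.4-fold higher number from compound 1 to compound 2 (0.14 log units; within the scatter) is a close relative of it. Neither moved the number beyond the scatter. For compound 4, therefore, a step of a 1.4-fold lower number from compound 3 to compound 4 (0.15 log units; within the scatter) is expected, leaning toward a lower number but not beyond the scatter. Compound 4 is estimated at 45000 nM, with a range from 20000 nM to 100000 nM.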

Compound 4, half-maximal inhibitory concentration: 34000 nM
The estimate for compound 4 lay 1.3-fold (0.12 log units) above the measured number; low and high end bracket the measured number.
By their numbers in this assay, from the lowest: compounds 1, 4, 2 and 3 (each within the scatter of the next, the first and the last beyond it).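

Among these compounds, with the chloro group held in place, 4-chlorophenyl in place of ((4-chlorophenyl)carbamoyl)amino on the amide-type nitrogen gives a 1.9-fold lower number from compound 3 to compound 4 (0.27 log units; within the scatter) in this assay, the first comparison here in which only the link differs. Swapping 3-chlorophenyl for 4-chlorophenyl at this nitrogen gives a 1.1-fold lower number from compound 2 to compound 4 (0.04 log units; within the scatter), so the two chlorophenyl tails cannot be told apart in this test. Compound 4 also stays close to the bromo semicarbazide, with a 1.3-fold higher number from compound 1 to compound 4 (0.10 log units; within the scatter), even though compound 1 and compound 3 are separated beyond the scatter.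

No measurement here offers a reason for these small differences.
Every tail shown ends in a chloro- or bromo-substituted phenyl ring, so it remains open whether a benzyl group or a carboxylic acid on that ring would shift the number beyond the scatter.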